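Triazole N-substituent swap in the ghrelin receptor antagonist series

The source may hold more compounds than are shown below. What is called first, only, known or untested is meant among the compounds shown, and "the series" means these compounds.

Measured compounds:
- compound 1 `COc1ccc(Cn2c(CCc3ccccc3)nnc2[C@H](NC(=O)C(C)(C)N)c2c[nH]c3ccccc23)cc1`: 5 nM
- compound 2 `COc1ccc(Cn2c(CCc3ccccc3)nnc2[C@H](NC(=O)c2ccncc2)c2c[nH]c3ccccc23)cc1`: "not determined" (no result reported)
- compound 3 `COc1ccc(-n2c(CCc3ccccc3)nnc2[C@H](NC(=O)Cc2ccccn2)c2c[nH]c3ccccc23)c(OC)c1`: 35 nM

In a functional assay on CHO cells for antagonist activity at growth hormone secretagogue receptor type 1 (Homo sapiens) (a higher number here means a weaker inhibitor, a lower number a stronger inhibitor), compound 1 gives 5 nM and compound 3 gives 35 nM. In this assay compound 2 gives "not determined" (no result reported), so no number is available for it. For the measured compounds named here, compound 3 therefore carries the higher of the two available numbers, and its gap to compound 1 lies beyond the scatter; compound 1 and compound 3 differ in more than one place, so no single step is counted between them.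

Compound 4 `COc1ccc(Cn2c(CCc3ccccc3)nnc2[C@H](NC(=O)Cc2ccccn2)c2c[nH]c3ccccc23)cc1` has not yet been measured. It differs from compound 3 in one place: 4-methoxybenzyl in place of 2,4-dimethoxyphenyl on an aromatic nitrogen. Going by the values given here, the group that enters is the one that compound 1 carries on the same aromatic nitrogen, while the amide of compound 4 remains that of compound 3.

Given that compound 1 gives 5 nM with this same group on the ring nitrogen, the expected step of a 2.9-fold lower number from compound 3 to compound 4 (0.46 log units; beyond the scatter) is toward a lower number, of moderate size and beyond the scatter, though this rests on two compounds only. For compound 4 the estimated value in this assay is 12 nM, with a range from 3 nM to 50 nM.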

Compound 4, antagonist equilibrium constant: 6 nM
For compound 4 the middle estimate is 2.0-fold (0.30 log units) above the measured one; measured number inside the range.
By their numbers in this assay, from the lowest: compounds 1 and 4 (each within the scatter of the next); then compound 3.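

For the compounds shown here, on the aromatic nitrogen, 4-methoxybenzyl in place of 2,4-dimethoxyphenyl gives a 5.8-fold lower number from compound 3 to compound 4 (0.77 log units; beyond the scatter) in this assay with the amide held constant, the first single-change reading at this position. With 4-methoxybenzyl fixed, (pyridin-2-yl)methyl in place of 1-amino-1-methylethyl on the carbonyl carbon gives a 1.2-fold higher number from compound 1 to compound 4 (0.08 log units; within the scatter), so the amine of compound 1 is not required for a value in this range. No supporting measurement bears on why the number moves with the change on the nitrogen.

This single step changes both the carbon link to the ring and the methoxy pattern, so the contribution of each remains unseparated. A 4-methoxyphenyl, a 2,4-dimethoxybenzyl or a longer chain such as 2-(4-methoxyphenyl)ethyl on the same nitrogen would address this.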